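The source may hold more compounds than are shown below. What is called first, only, known or untested is meant among the compounds shown, and "the series" means these compounds.

Measured so far:

Compound 1 `COc1cc2c(C(=O)/C=C(\O)C(=O)O)cn(Cc3ccc(F)cc3)c2cc1OC` gives 65500 nM in an ADME assay on MT4 cells (Homo sapiens) for cytotoxicity, read by MTT assay; a higher number here means that more compound is tolerated, a lower number that less compound is tolerated.
Compound 2 `COc1ccc2c(C(=O)/C=C(\O)C(=O)O)cn(Cc3ccc(F)cc3)c2c1OC` gives 131000 nM in this assay.
Compound 3 `CCOC(=O)/C(O)=C/C(=O)c1cn(Cc2ccc(F)cc2)c2cc(OC)c(OC)cc12` gives 21800 nM in this assay.

Compound 1 and compound 2 are built from the same atoms joined differently; the difference between the two cores is not broken down here. What compound 2 and compound 1 show is a gap that lies within the scatter. From compound 1 to compound 3 the change is ethyl in place of hydrogen on an oxygen next to a carbonyl group, and it gave a 3.0-fold lower number from compound 1 to compound 3 (0.48 log units; beyond the scatter). Compound 4 `CCOC(=O)/C(O)=C/C(=O)c1cn(Cc2ccc(F)cc2)c2c(OC)c(OC)ccc12` has not yet been measured. It differs from compound 2 by ethyl in place of hydrogen on an oxygen next to a carbonyl group, the same change in the same place, so the step is expected to be a 3.0-fold lower number from compound 2 to compound 4 (0.47 log units; beyond the scatter) in this assay. This rests on one pair only, compound 1 to compound 3, so it is a loose expectation. Compound 4 is therefore expected to give 44000 nM, likely between 20000 nM and 95000 nM.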

Compound 4, half-maximal cytotoxic concentration: 119000 nM
Compound 4: middle estimate off by 2.7-fold (0.43 log units), on the low side; the whole stated range lies below it.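

Putting ethoxycarbonyl in place of carboxy gave a 1.1-fold lower number from compound 2 to compound 4 (0.04 log units; within the scatter) in this assay. The same change therefore did not have the same effect on the two cores: the same change on two cores in this assay, a 3.0-fold lower number (0.48 log units; beyond the scatter) from compound 1 to compound 3 and a 1.1-fold lower number (0.04 log units; within the scatter) from compound 2 to compound 4, 2.7-fold (0.44 log units) apart, beyond the scatter of two such steps

So in these two pairs, the size of the step depends on the core it is made on; the pairs do not show why, and they give no rule for any other core. The compounds shown carry only carboxy or ethoxycarbonyl at this place, so a methyl ester, a longer chain on that oxygen or an amide remains open. Also open, from the compounds shown here alone, is whether the two cores would differ in the same way with those groups.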